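Butoxy in place of chloro on the aromatic ring

This account rests on a few compounds, and the source may have more. Where it says the series, first, only, none or still open, it means among the compounds named here.

For the measured compounds named here, in a functional assay on M21 cells (Homo sapiens) for antiproliferative activity, read by sulforhodamine B assay, with a stated time of 48 h (a higher number here means a weaker inhibitor, a lower number a stronger inhibitor), compound 2 `O=C1NCCN1c1ccc(S(=O)(=O)Nc2ccc(Cl)cc2)cc1` gives 90 nM, the only actual number so far. Compound 1 `CC(C)(C)c1ccc(NS(=O)(=O)c2ccc(N3CCNC3=O)cc2)cc1` gives > 1000 nM, which is a limit of the assay. Compound 3 `CCCCOc1ccc(NS(=O)(=O)c2ccc(N3CCNC3=O)cc2)cc1` has butoxy in place of chloro on an aromatic carbon. Going by the values given here, one measured step bears on this change: an at least 11-fold lower number from compound 1 to compound 2 (1.04 log units; beyond the scatter), which is large and favours chloro over tert-butyl. Among the compounds with values here, with only this step as a guide, a clear rise in the number is expected in this assay, and the expected change is a 5.6-fold higher number from compound 2 to compound 3 (0.74 log units; beyond the scatter). For compound 3 the estimate is 500 nM, with an expected range of 130 nM to 2000 nM.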

Compound 3, half-maximal inhibitory concentration: 580 nM
Estimate against measurement, compound 3: 1.2-fold (0.06 log units) below; the range from low to high includes it.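

In this assay the change gives a 6.4-fold higher number from compound 2 to compound 3 (0.81 log units; beyond the scatter) and so places butoxy behind chloro on this aromatic carbon. With tert-butyl also behind chloro, compound 2 now leads both other groups at this position, and an oxygen-linked chain does not restore its activity. The remaining step, an at least 1.7-fold lower number from compound 1 to compound 3 (0.23 log units; that floor lies within the scatter), rests on a limit and does not order butoxy against tert-butyl: the limit of > 1000 nM in this assay, at which 1 of the 3 values shown sits.

Going by these compounds, whether fluoro, methoxy or an amine here would match chloro remains open. So does whether a shorter or longer alkoxy chain would shift the number from that of compound 3.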